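Bromo for acetoxy on the shared core

This account rests on a few compounds, and the source may have more. Where it says the series, first, only, none or still open, it means among the compounds named here.

Compound 1 `CC(=O)O[C@@H]1OC(=O)[C@](C)(C(C)=O)[C@@H]1C` gives 7000 nM in a functional assay on DA-3 cells for cytotoxicity against DA-3 cell line (Mus musculus), read by MTT assay; on this read-out higher numbers stand for weaker inhibition and lower numbers for stronger inhibition.
Compound 2 `CC(=O)O[C@@H]1OC(=O)[C@](Cc2ccccc2)(C(C)=O)[C@@H]1C` gives 45000 nM in this assay.
Compound 3 `CC(=O)O[C@@H]1OC(=O)[C@](OC(C)=O)(C(C)=O)[C@@H]1C` gives only a limit of the assay, > 50000 nM in this assay.

Compound 3 therefore stands at the weak end of the numbers shown, with no figure of its own, as the limit of > 50000 nM in this assay, at which 1 of the 3 values shown sits, records. Compound 4 `CC(=O)O[C@@H]1OC(=O)[C@](Br)(C(C)=O)[C@@H]1C` differs from it by bromo in place of acetoxy on a saturated ring carbon. Two measured steps lead to the same ring carbon: an at least 7.1-fold higher number from compound 1 to compound 3 (0.85 log units; beyond the scatter) and an at least 1.1-fold higher number from compound 2 to compound 3 (0.04 log units; that floor lies within the scatter). Among the measured compounds shown here, the only group smaller than acetoxy at that carbon is the methyl of compound 1, and bromo is likewise a single heavy atom there, so the step from compound 3 is expected to run back toward the value of compound 1, though the limit of compound 3 leaves its size open. For compound 4 a lower number is expected, an at least 3.3-fold lower number from compound 3 to compound 4 (0.52 log units; beyond the scatter). Compound 4 is estimated at 15000 nM, between 4000 nM and 60000 nM.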

Compound 4, half-maximal inhibitory concentration: 6000 nM
Beside the measured number, compound 4's estimate is 2.5-fold (0.40 log units) above it, within the range that was stated.
By their numbers in this assay, from the lowest: compounds 4 and 1 (each within the scatter of the next); then compound 2. At a limit, above all of these: compound 3.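

Methyl is no longer the only group on this saturated ring carbon that holds the lower numbers, as bromo cannot be told apart from it in this assay: a 1.2-fold lower number from compound 1 to compound 4 (0.07 log units; within the scatter). The same replacement separates bromo clearly from the two other groups, with a 7.5-fold lower number from compound 2 to compound 4 (0.88 log units; beyond the scatter) and an at least 8.3-fold lower number from compound 3 to compound 4 (0.92 log units; beyond the scatter). The step from acetoxy is only a floor, as compound 3 records a limit of the assay: the limit of > 50000 nM in this assay, at which 1 of the 4 values shown sits.

The compounds shown leave open whether an amine, a hydroxyl group or a longer alkyl chain on this carbon would keep the number at the level of methyl and bromo or move it toward that of benzyl. On these data alone, the true size of the gap between acetoxy and bromo also remains unknown.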